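The compounds below may be only part of what the source reports. "The series", "measured", "known", "first", "only" and "open" are said of these compounds alone.

Working notes on the series, all read in a functional assay on LN-229 cells (Homo sapiens) for antiproliferative activity, with a stated time of 72 h; on this read-out lower numbers stand for stronger inhibition and higher numbers for weaker inhibition. Compound 1 `Nc1ncnn2c([C@@H]3O[C@H](CO)[C@@H](O)[C@H]3O)cc(C#Cc3ccccc3)c12` gives 88000 nM. Compound 2 `COc1ccc(-c2cc([C@@H]3O[C@H](CO)[C@@H](O)[C@H]3O)n3ncnc(N)c23)cc1` gives 40300 nM. Compound 3 `Cc1ccccc1-c1cc([C@@H]2O[C@H](CO)[C@@H](O)[C@H]2O)n2ncnc(N)c12` is reported only as a limit, > 100000 nM, so its place among the three is bounded on one side and is not a number.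

Compound 4 `Nc1ncnn2c([C@@H]3O[C@H](CO)[C@@H](O)[C@H]3O)cc(/C=C/c3ccccc3)c12` follows from compound 3 by one change: 2-phenylethenyl in place of 2-methylphenyl on an aromatic carbon. This puts 2-phenylethenyl in place of 2-methylphenyl on an aromatic carbon of the five-membered aromatic ring.

Three measured swaps at this same place bear on the change. The first gives a 2.2-fold lower number from compound 1 to compound 2 (0.34 log units; beyond the scatter), a modest step. The second gives an at least 2.4-fold higher number from compound 2 to compound 3 (0.39 log units; beyond the scatter), at least modest. The third gives an at least 1.1-fold higher number from compound 1 to compound 3 (0.05 log units; that floor lies within the scatter), with a floor inside the scatter. The group closest by name to the entering one is the 2-phenylethynyl of compound 1, which gives 88000 nM. With steps of this size at this place, a modest move towards a lower number is expected, and a result at the limit of the assay remains possible. The expected change is an at least 1.6-fold lower number from compound 3 to compound 4 (0.22 log units; that floor lies within the scatter). For compound 4 the estimated value is 60000 nM, with an expected range from 25000 nM to 100000 nM.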

Compound 4, half-maximal inhibitory concentration: 3900 nM
Compound 4: the middle estimate sits 15-fold (1.19 log units) above what was measured, and the stated range ends above it.
By their numbers in this assay, from the lowest: compound 4; then compound 2; then compound 1. At a limit, above all of these: compound 3.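

At this aromatic carbon of the five-membered aromatic ring, 2-phenylethenyl gives large steps in this assay, a 10-fold lower number from compound 2 to compound 4 (1.01 log units; beyond the scatter) and a 23-fold lower number from compound 1 to compound 4 (1.35 log units; beyond the scatter), where the earlier compounds had shown only a modest step and two floors. Compound 1 and compound 4 both end in a phenyl ring and differ in the link to it, the triple bond of 2-phenylethynyl against the double bond of 2-phenylethenyl, so a terminal phenyl ring alone does not set the read-out at this position. Compound 3 is held at a limit and not at a number, which leaves an at least 25-fold lower number from compound 3 to compound 4 (1.40 log units; beyond the scatter) as a floor, with its full size unread: the limit of > 100000 nM in this assay, at which 1 of the 4 values shown sits.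

The compounds shown do not tell whether the large step belongs to the double bond itself or to the spacing of the phenyl ring from the shared core, and a saturated 2-phenylethyl chain at this place would bear on that question. On these data alone, how far the 2-phenylethenyl group tolerates change also stays open, for instance a methoxy group or a fluorine on its phenyl ring, or a pyridine ring in place of that phenyl ring.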